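Quinoline carboxamides: ethoxy for fluoro on the carbocyclic ring

The source may hold more compounds than are shown below. What is called first, only, known or untested is meant among the compounds shown, and "the series" means these compounds.

Three compounds have been measured in a functional assay on Hep 3B2 cells (Homo sapiens) for antiproliferative activity, read by MTT assay, with a stated time of 24 h, tested at 100 ug/mL; a higher number here means a stronger effect of the compound at the concentration tested, a lower number a weaker effect:

compound 1 `Cc1c(C(=O)Nc2c(F)cc(-c3cccc(F)c3)cc2F)nc2ccc(F)cc2c1O` gives 75.2%
compound 2 `CCOc1ccc2nc(C(=O)Nc3c(F)cc(-c4cccc(F)c4)cc3F)c(C)c(O)c2c1` gives 33.3%
compound 3 `Cc1c(C(=O)Nc2c(F)cc(-c3cccc(F)c3)cc2F)nc2ccc(F)cc2c1C(=O)O` gives 65.2%

Two single changes connect them. The change ethoxy in place of fluoro on an aromatic carbon carries the step of a number 41.9 percentage points lower from compound 1 to compound 2 (beyond the scatter). The change of core, (carboxy in place of hydroxy on an aromatic carbon), carries the step of a number 10 percentage points lower from compound 1 to compound 3 (within the scatter); compound 3 thus stands second of the three numbers, with compound 2 the furthest away.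

Compound 4 `CCOc1ccc2nc(C(=O)Nc3c(F)cc(-c4cccc(F)c4)cc3F)c(C)c(C(=O)O)c2c1` is not yet measured. Its difference from compound 3 is ethoxy in place of fluoro on an aromatic carbon; the place is described in the same words as for the change from compound 1 to compound 2, so this is the same change set on the core of compound 3. The step from compound 3 to compound 4 is expected to be of the same kind and size, a number 40.2 percentage points lower from compound 3 to compound 4 (beyond the scatter), because the same change on the other core gave a number 41.9 percentage points lower from compound 1 to compound 2 (beyond the scatter). The expected value for compound 4 in this assay is therefore 25%, with a range from 10% to 45%.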

Compound 4, a percentage reported as inhibition, at one concentration (the size of the read-out at that concentration, not a potency): 65.3%
Estimate against measurement, compound 4: 40.3 percentage points below; measured number outside the range, above it.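

In this assay, ethoxy in place of fluoro does not carry over from the core of compound 1 to the core of compound 3: here it gives a number 0.1 percentage points higher from compound 3 to compound 4 (within the scatter), and the two steps differ: the same change on two cores in this assay, a number 41.9 percentage points lower (beyond the scatter) from compound 1 to compound 2 and a number 0.1 percentage points higher (within the scatter) from compound 3 to compound 4, 42 percentage points apart, beyond the scatter of two such steps. Read the other way, carboxy in place of hydroxy gives a number 32 percentage points higher from compound 2 to compound 4 (beyond the scatter), which also departs from its counterpart in the fluoro pair: the same change on two cores in this assay, a number 10 percentage points lower (within the scatter) from compound 1 to compound 3 and a number 32 percentage points higher (beyond the scatter) from compound 2 to compound 4, 42 percentage points apart, beyond the scatter of two such steps. Across these compounds the two changes therefore do not add, and the drop with ethoxy appears only in the pair carrying hydroxy, but one such pair of cores gives no rule for other cores and does not show why the steps differ.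

As far as these compounds go, it remains open whether a longer chain than ethoxy or a chlorine on that aromatic carbon would follow the drop seen with compound 2 or the flat step seen with compound 4. From the compounds shown here alone, it also remains open how an amine or an ester in place of the hydroxy or carboxy group would behave.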